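The source may hold more compounds than are shown below. What is called first, only, known or untested is meant among the compounds shown, and "the series" means these compounds.

Measured compounds:
compound 1 `Cc1cc(C(=O)O)ccc1OCCCCOc1ccc(C(=O)CC(C)C)c(O)c1C` — 192 nM
compound 2 `Cc1c(OCCCCOc2ccccc2C(=O)O)ccc(C(=O)CC2CCCC2)c1C` — 2580 nM

In an assay on HEK293 cells for positive allosteric modulation of metabotropic glutamate receptor 2 (Rattus norvegicus), read by thallium flux, with a stated time of 2.5 min (on this read-out lower numbers stand for an effect already at smaller amounts and higher numbers for an effect only at larger amounts of compound), compound 1 gives 192 nM, the lower of the two numbers; compound 2 gives 2580 nM, a number higher by a margin beyond the scatter. Among the measured compounds shown here, no single-change step connects these two, so they are read only as two points. Compound 3 `Cc1c(OCCCCOc2ccc(C(=O)O)cc2F)ccc(C(=O)CC(C)C)c1O` is the untested partner of compound 1: fluoro in place of methyl on an aromatic carbon. Without a measured step of this kind to lean on, a step of modest size from compound 1 to compound 3 is expected, a 1.6-fold higher number from compound 1 to compound 3 (0.19 log units; within the scatter), at most around the edge of the scatter and in either direction. Compound 3 is estimated at 300 nM, with a range from 100 nM to 900 nM.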

Compound 3, half-maximal effective concentration: 102 nM
Compound 3: the middle estimate sits 2.9-fold (0.47 log units) above what was measured, and the stated range covers the measured number.
By their numbers in this assay, from the lowest: compounds 3 and 1 (each within the scatter of the next); then compound 2.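

In this assay, among the compounds shown here, fluoro in place of methyl on this aromatic carbon, ortho to a large group and meta to a carboxy group, gives a 1.9-fold lower number from compound 1 to compound 3 (0.27 log units; within the scatter), the only single-change step available. The two compounds therefore cannot be told apart, and at this position, within this pair, fluoro serves as well as methyl. No measurement shown here accounts for this result.

On these data alone, what remains open is whether plain hydrogen, chloro, methoxy or trifluoromethyl on this carbon would also leave the number within the scatter. As far as these compounds go, it is also open whether the same exchange would read alike with a different ketone side chain.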